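The compounds below may be only part of what the source reports. "The series", "measured", "known", "first", "only" and "open" are said of these compounds alone.

Measured so far in a functional assay on B16-F10 cells (Mus musculus) for antiproliferative activity, read by MTT assay, with a stated time of 48 h; on this read-out lower numbers stand for stronger inhibition and higher numbers for weaker inhibition

Compound 1 `Cc1ccc(NCc2cn(-c3ccccc3)nc2-c2ccc(Cl)cc2)cc1` gives 3480 nM
Compound 2 `Fc1ccc(NCc2cn(-c3ccccc3)nc2-c2ccc(Cl)cc2)cc1` gives 2120 nM
Compound 3 `Clc1ccc(-c2nn(-c3ccccc3)cc2CNc2ccc(Br)cc2)cc1` gives 3010 nM

Compound 3 at 3010 nM lies within the scatter of both other compounds. Compound 4 `Clc1ccc(NCc2cn(-c3ccccc3)nc2-c2ccc(Cl)cc2)cc1` has yet to be measured and differs from compound 3 by one exchange (chloro in place of bromo on an aromatic carbon) with chloro in place of bromo on an aromatic carbon, para to a large group. Three measured exchanges on that aromatic carbon bear on it (a 1.2-fold lower number from compound 1 to compound 3 (0.06 log units; within the scatter)) and (a 1.4-fold higher number from compound 2 to compound 3 (0.15 log units; within the scatter)) and (a 1.6-fold lower number from compound 1 to compound 2 (0.22 log units; within the scatter)) and each stayed within the scatter. No step beyond the scatter is therefore expected in this assay and the estimated step is small (a 1.1-fold lower number from compound 3 to compound 4 (0.05 log units; within the scatter)). Compound 4 is estimated at 2700 nM with an expected range from 1700 nM to 4200 nM in this measurement.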

Compound 4, half-maximal inhibitory concentration: 2450 nM
For compound 4 the middle estimate is 1.1-fold (0.04 log units) above the measured one; measured number inside the range.
By their numbers in this assay, from the lowest: compounds 2, 4, 3 and 1 (each within the scatter of the next).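

In this assay, chloro on this aromatic carbon, para to a large group, does not separate from bromo (a 1.2-fold lower number from compound 3 to compound 4 (0.09 log units; within the scatter)), from fluoro (a 1.2-fold higher number from compound 2 to compound 4 (0.06 log units; within the scatter)) or from methyl (a 1.4-fold lower number from compound 1 to compound 4 (0.15 log units; within the scatter)). All four groups at this place now lie within the scatter of one another, so this read-out gives them no order. Nothing measured here offers an explanation for this. Still open, on these data alone, is whether an amine, a carboxylic acid or a methoxy group at this place would give a step beyond the scatter.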